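A few compounds are considered here, and "the series" means these few. Any claim that something is new, unique, unknown or untested is made for them only; others in the source may bear on it.

Within the data shown here, compound 1 `COCC(=O)N(Cc1ccc(OC)c(O)c1)c1cc(OC)c(OC)c(OC)c1` sits at the strong end of the three compounds measured so far. In a functional assay on KYSE-450 cells (Homo sapiens) for inhibition, read by MTT assay, with a stated time of 48 h (on this read-out higher numbers stand for weaker inhibition and lower numbers for stronger inhibition), compound 1 gives 460 nM, the lowest of the three numbers. Compound 2 `COc1ccc(N(Cc2cc(OC)c(OC)c(OC)c2)C(=O)CCl)cc1O` gives 29800 nM in this assay, and compound 3 `C/C=C/C(=O)N(Cc1ccc(OC)c(C)c1)c1cc(OC)c(OC)c(OC)c1` gives 32900 nM; both numbers lie well beyond the usual scatter away from the number of compound 1, so compound 1 is clearly the strongest inhibitor of the three. Neither compound 2 nor compound 3 differs from compound 1 in a single place, so no single change can be read off from them.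

Compound 4 `COc1ccc(CN(C(=O)/C=C/CBr)c2cc(OC)c(OC)c(OC)c2)cc1O` has not been measured. It differs from compound 1 in one place (3-bromoprop-1-en-1-yl in place of methoxymethyl on a carbonyl carbon). Among the measured compounds shown here, no measured pair shows this change on its own, so the direction of the step is open. A shift from compound 1 toward weaker inhibition is expected, with the step of a 3.3-fold higher number from compound 1 to compound 4 (0.51 log units; beyond the scatter) read as larger than the scatter. Compound 4 is therefore expected to give about 1500 nM in this assay, within a range from 300 nM to 8000 nM.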

Compound 4, half-maximal inhibitory concentration: 100 nM
Estimate against measurement, compound 4: 15-fold (1.18 log units) above; measured number outside the range, below it.
By their numbers in this assay, from the lowest: compound 4; then compound 1; then compounds 2 and 3 (each within the scatter of the next).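

Among these compounds, on the carbonyl carbon whose other neighbour is the amide-type nitrogen, this assay now gives a first direct reading of a single change: replacing methoxymethyl with 3-bromoprop-1-en-1-yl produces a 4.6-fold lower number from compound 1 to compound 4 (0.66 log units; beyond the scatter), a modest move toward stronger inhibition. The earlier compounds shown here could not show this, as none of them differed from compound 1 in only one place. The new group has no oxygen and brings a bromine and a double bond, yet inhibition does not weaken, and no measurement here explains the step.

On these data alone, it remains open whether the bromine, the double bond or the chain as a whole accounts for the lower number, which a plain prop-1-en-1-yl group on the same core could help separate. As far as these compounds go, how an amine or a carboxylic acid would behave at this position also remains unknown.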